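Amide side chain swap and tolerated concentration

A few compounds are considered here, and "the series" means these few. Any claim that something is new, unique, unknown or untested is made for them only; others in the source may bear on it.

Compound 2 `Cc1cc(CNC(=O)c2cc3nc(C)c([C@H](OC(C)(C)C)C(=O)O)c(-c4cc(F)c5c(c4C)CCCO5)n3n2)ccc1F` is one of three measured members of the series. In an ADME assay on MT2 cells (Homo sapiens) for cytotoxicity (a higher number here means that more compound is tolerated, a lower number that less compound is tolerated), compound 2 gives > 40000 nM, which is a limit of the assay and not a number. Compound 1 `Cc1nc2cc(C(=O)NCc3ccc(F)cc3)nn2c(-c2cc(F)c3c(c2C)CCCO3)c1[C@H](OC(C)(C)C)C(=O)O` gives > 40000 nM in this assay, again a limit. Compound 3 `Cc1nc2cc(C(=O)NCCC(C)C)nn2c(-c2cc(F)c3c(c2C)CCCO3)c1[C@H](OC(C)(C)C)C(=O)O` gives > 40000 nM in this assay, also a limit. Compound 2 therefore stands exactly where the other two stand, namely at the limit of > 40000 nM in this assay, at which 3 of the 3 values shown sit. The step that the two limits leave unreadable from compound 1 to compound 2 cannot be read for this reason, and neither can a step that the two limits leave unreadable from compound 1 to compound 3 or a step that the two limits leave unreadable from compound 2 to compound 3.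

Compound 4 `Cc1nc2cc(C(=O)NCCC(C)(C)C)nn2c(-c2cc(F)c3c(c2C)CCCO3)c1[C@H](OC(C)(C)C)C(=O)O` is not yet measured. It differs from compound 2 in one place: neopentyl in place of 4-fluoro-3-methylphenyl on a saturated chain carbon bound to an amide-type nitrogen. The measured step that bears on this most closely is a step that the two limits leave unreadable from compound 2 to compound 3, in which a saturated chain likewise took the place of an aryl group on the same carbon; its size stays hidden because both of its values sit at the limit of > 40000 nM in this assay, at which 3 of the 3 values shown sit. Among the measured compounds shown here, no measured step gives a readable size, so no change beyond the scatter can be argued for or against. The expected step is a number no higher from compound 2 to compound 4 (the limit leaves the size open), and the read-out is expected to return a limit once more. Compound 4 is expected to give 40000 nM in this assay, within 20000 nM to 80000 nM.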

Compound 4, half-maximal cytotoxic concentration: > 40000 nM
Compound 4: a limit, no number; the forecaster's own chance of this, stated with the estimate: 85%; the middle value sits exactly at the limit.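

In this assay compound 4 gives > 40000 nM, a limit and not a number. The steps to compound 4 from compound 1, compound 2 and compound 3 cannot be read, because all four values share one limit: the limit of > 40000 nM in this assay, at which 4 of the 4 values shown sit.

The compounds shown leave open whether these amide side chains differ at all in the tolerated concentration.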